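This account rests on a few compounds, and the source may have more. Where it says the series, first, only, none or still open, it means among the compounds named here.

Measured so far:
compound 1 `CN1CCC(C(=O)N2Cc3c(NC(=O)C4CCC4)n[nH]c3C2(C)C)CC1` – 140 nM
compound 2 `CC(C)CC(=O)Nc1n[nH]c2c1CN(C(=O)C1CCN(C3CC3)CC1)C2(C)C` – 320 nM
compound 3 `CC(=O)N1CCN(C(=O)N2Cc3c(NC(=O)c4ccc(F)cc4)n[nH]c3C2(C)C)CC1` – a limit, > 10000 nM

In a functional assay on A2780 cells (Homo sapiens) for antiproliferative activity, read by fluorescence, with a stated time of 72 h (a lower number here means a stronger inhibitor, a higher number a weaker inhibitor), compound 1 gives 140 nM, the lowest of the two numbers shown, with compound 2 giving 320 nM. Compound 3 reaches only the limit of the assay, (the limit of > 10000 nM in this assay, at which 1 of the 3 values shown sits). Compound 4 `CN1CCC(C(=O)N2Cc3c(NC(=O)c4cc(F)cc(F)c4)n[nH]c3C2(C)C)CC1` is not yet measured; it differs from compound 1 in one place: 3,5-difluorophenyl in place of cyclobutyl on a carbonyl carbon. Going by the values given here, no measured pair shows this change alone, so the step from compound 1 to compound 4 in this assay is estimated to be a weakening beyond the scatter, a 7.1-fold higher number from compound 1 to compound 4 (0.85 log units; beyond the scatter). Compound 4 is expected to give about 1000 nM, within a range of 200 nM to 6000 nM.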

Compound 4, half-maximal inhibitory concentration: 130 nM
Beside the measured number, compound 4's estimate is 7.7-fold (0.89 log units) above it; the whole stated range lies above it.
By their numbers in this assay, from the lowest: compounds 4 and 1 (each within the scatter of the next); then compound 2. At a limit, above all of these: compound 3.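

In this assay, the change on this carbonyl carbon gives a 1.1-fold lower number from compound 1 to compound 4 (0.03 log units; within the scatter), so cyclobutyl and 3,5-difluorophenyl cannot be told apart here. This position therefore takes an aromatic ring of 8 heavy atoms as well as a non-aromatic ring of 4, at least when the rest of compound 1 stays the same. Nothing measured here explains why the two groups match.

Going by these compounds, it remains open how this position would respond to a carboxylic acid, an amine or a longer carbon chain on the carbonyl carbon. On these data alone, it is also open whether the same swap would give a matching result with a different group on the other side of the core.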